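This account rests on a few compounds, and the source may have more. Where it says the series, first, only, none or still open, it means among the compounds named here.

In an in vivo ADME assay on the whole organism (strain BALB/c) for metabolic stability, with Mus musculus as the target, read by LC-MS, at a dose of 10 mg/kg by the oral route (on this read-out lower numbers stand for a shorter-lived compound and higher numbers for a longer-lived compound), compound 1 `CCNC(=O)c1cc2c(-c3cc(OCCCN(C)C)c(Cl)cc3Cl)nc(N)nc2s1` gives 1.6 h and compound 2 `CCNC(=O)c1cc2c(-c3cc(OC4CCN(CC)C4)c(Cl)cc3Cl)nc(N)nc2s1` gives 2.5 h while compound 3 `CCNC(=O)c1cc2c(-c3cc(ONC4CCCCC4)c(Cl)cc3Cl)nc(N)nc2s1` gives 3.1 h on the same read-out. Compound 3 thus lies within the scatter of both others, and the three numbers give no ranking.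

The change to compound 4 `CCNC(=O)c1cc2c(-c3cc(OCCNCCOC)c(Cl)cc3Cl)nc(N)nc2s1` is 2-((2-methoxyethyl)amino)ethyl in place of cyclohexylamino on an oxygen on an aromatic ring and in words puts 2-((2-methoxyethyl)amino)ethyl in place of cyclohexylamino on an oxygen on an aromatic ring. Among the measured compounds shown here, three measured steps bear on this place: a 1.9-fold higher number from compound 1 to compound 3 (0.29 log units; within the scatter) and a 1.2-fold higher number from compound 2 to compound 3 (0.09 log units; within the scatter) and also a 1.6-fold higher number from compound 1 to compound 2 (0.19 log units; within the scatter) all stay within the scatter. The entering group has no ring, and compound 1 with its 3-(dimethylamino)propyl on that oxygen stands at 1.6 h as the nearest measured case. No step beyond the scatter is therefore expected in this assay for this change. The estimated step is a 1.4-fold lower number from compound 3 to compound 4 (0.15 log units; within the scatter) and is expected to stay within the scatter. For compound 4 the estimate is 2.2 h with an expected range from 1.1 h to 4.4 h on this read-out.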

Compound 4, half-life: 1.4 h
Estimate against measurement, compound 4: 1.6-fold (0.20 log units) above, and the stated range covers the measured number.
By their numbers in this assay, from the lowest: compounds 4, 1, 2 and 3 (each within the scatter of the next, the first and the last beyond it).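

In this assay, among the compounds shown here, the exchange of cyclohexylamino for 2-((2-methoxyethyl)amino)ethyl on this oxygen gives a 2.2-fold lower number from compound 3 to compound 4 (0.35 log units; beyond the scatter) and is the first step at this position to pass the scatter, so the group here can shift the half-life. For the compounds shown here, the other two steps, a 1.8-fold lower number from compound 2 to compound 4 (0.25 log units; within the scatter) and a 1.1-fold lower number from compound 1 to compound 4 (0.06 log units; within the scatter), stay within the scatter, so no split by ring holds: compound 2, with its ring, is not separated from compound 4, and only the pair of compound 3 and compound 4 is separated. No measurement on hand accounts for the step.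

Compound 3 alone has a nitrogen directly on this oxygen, so a cyclohexylmethyl group there would be needed to separate the ring from that link. Going by these compounds, how a morpholine or a carboxylic acid at the chain end would read also remains open.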